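A few compounds are considered here, and "the series" means these few. Any claim that something is new, unique, unknown or untested is made for them only; others in the source may bear on it.

Measured so far, in a functional assay on WRL68 cells (Homo sapiens) for cytotoxicity, read by MTT assay, with stated times of 6 h and 48 h; on this read-out higher numbers stand for weaker inhibition and lower numbers for stronger inhibition:
- compound 1 `COc1ccc(OC)c(C(=O)/C=C/c2cc(Br)c(Br)n2C)c1`: 3270 nM
- compound 2 `COc1ccc(OC)c(C(=O)/C=C/c2cc(Br)c(Br)[nH]2)c1`: 12300 nM
- compound 3 `O=c1cc(-c2cc(Br)c(Br)[nH]2)oc2ccccc12`: a limit of the assay, >= 100000 nM

Compound 2 and compound 1 share one core and differ only in methyl in place of hydrogen on an aromatic nitrogen. In this assay the step runs a 3.8-fold lower number from compound 2 to compound 1 (0.58 log units; beyond the scatter), so the methyl on the aromatic nitrogen goes with the lower number here.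

Compound 3 carries a different core; the difference between the two cores is not broken down here. For compound 3 this assay reports only a limit, (the limit of >= 100000 nM in this assay, at which 1 of the 3 values shown sits), and no number.

Compound 4 `Cn1c(-c2cc(=O)c3ccccc3o2)cc(Br)c1Br` has not been measured. It stands to compound 3 as compound 1 stands to compound 2: the difference is methyl in place of hydrogen on an aromatic nitrogen, the same change at the same place on the five-membered ring.

Among the measured compounds shown here, the expectation for compound 4 in this assay is an estimate of an at least 1.6-fold lower number from compound 3 to compound 4 (0.22 log units; that floor lies within the scatter), set beside the measured step from compound 2 to compound 1 and resting on that step, a 3.8-fold lower number from compound 2 to compound 1 (0.58 log units; beyond the scatter), being the only example of this change in the set. From the compounds shown here alone, because compound 3 itself gives only the limit >= 100000 nM, the starting point is unknown, and compound 4 is expected either to return a number or again to sit at the limit. The estimate for compound 4 is 60000 nM, with a range from 20000 nM to 200000 nM.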

Compound 4, half-maximal inhibitory concentration: >= 100000 nM
Compound 4 was reported as a limit (the forecaster's own chance of this, stated with the estimate: 45%); middle value at least 1.6-fold (0.22 log units) from the limit.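

In this assay, compound 3 and compound 4 each give a limit and no number, so no step can be read between them: the limit of >= 100000 nM in this assay, at which 2 of the 4 values shown sit.

The compounds shown leave open whether methyl in place of hydrogen on an aromatic nitrogen changes the number on the core of compound 3 at all, and whether any such change would match a 3.8-fold lower number from compound 2 to compound 1 (0.58 log units; beyond the scatter).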